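Lengthening the isothiocyanate chain of compound 3

The source may hold more compounds than are shown below. What is called first, only, known or untested is meant among the compounds shown, and "the series" means these compounds.

Compound 1 `CN(C)C(=O)c1cc2cnc(Nc3ccc(S(=O)(=O)NCCCCN=C=S)cc3)nc2n1C1CCCC1` gives 39.4% in a functional assay on A549 cells (Homo sapiens) for inhibition, read by CCK-8 assay, with a stated time of 72 h, tested at 1 uM; a lower number here means a weaker effect, a higher number a stronger effect of the compound at the concentration tested.
Compound 2 `CN(C)C(=O)c1cc2cnc(Nc3ccc(C(=O)NCCCCCN=C=S)cc3)nc2n1C1CCCC1` gives 29.3%.
Compound 3 `CN(C)C(=O)c1cc2cnc(Nc3ccc(NC(=O)CCCCN=C=S)cc3)nc2n1C1CCCC1` gives 38.2%.

All three share one core and differ only in the chain that carries the isothiocyanate. Compound 3 stands second highest of the three numbers, with compound 1 nearest (a number 1.2 percentage points lower from compound 1 to compound 3 (within the scatter)) and compound 2 furthest (a number 8.9 percentage points higher from compound 2 to compound 3 (within the scatter)), so compound 3 is not separated from either by more than the scatter.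

Compound 4 `CN(C)C(=O)c1cc2cnc(Nc3ccc(NC(=O)CCCCCN=C=S)cc3)nc2n1C1CCCC1` differs from compound 3 in one place: a group of 4 heavy atoms (2 carbon, 1 nitrogen, 1 sulfur; no ring) in place of a group of 3 heavy atoms (1 carbon, 1 nitrogen, 1 sulfur; no ring), on a saturated chain carbon, four bonds along the chain from a carbonyl carbon. This adds one carbon to the chain while the amide linker stays the same.

For the measured compounds named here, two measured steps touch on chain length, but each also changes the linker. The step of a number 10.1 percentage points lower from compound 1 to compound 2 (beyond the scatter) was modest and beyond the scatter; the step of a number 8.9 percentage points higher from compound 2 to compound 3 (within the scatter) went the other way and stayed within it. Neither isolates the chain length alone, so the evidence is weak, and a step of no more than the scatter is expected, leaning slightly downward.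

Compound 4 is therefore estimated at 34%, in a range from 22% to 46%, which means an expected step of a number 4.2 percentage points lower from compound 3 to compound 4 (within the scatter).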

Compound 4, a percentage reported as inhibition, at one concentration (the size of the read-out at that concentration, not a potency): 56.1%
Estimate against measurement, compound 4: 22.1 percentage points below; the measured number lies above the stated range.
By their numbers in this assay, from the lowest: compounds 2, 3 and 1 (each within the scatter of the next, the first and the last beyond it); then compound 4.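

Compound 3 and compound 4 share the same amide linker, so this pair isolates chain length: in this assay, one added carbon on a saturated chain carbon, four bonds along the chain from a carbonyl carbon, gives a number 17.9 percentage points higher from compound 3 to compound 4 (beyond the scatter). Length alone does not set the number, however, since the chains of compound 2 and compound 4 are built from the same atoms with the amide turned round, and that change gives a number 26.8 percentage points higher from compound 2 to compound 4 (beyond the scatter), while the sulfonamide-linked chain differs in both linker and length and gives a number 16.7 percentage points higher from compound 1 to compound 4 (beyond the scatter). Nothing shown here accounts for the gain at this position, so it stands as an observation without an explanation.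

The compounds shown leave open whether a longer chain on the same amide linker would raise the number further or lower it again, as a single step cannot show a trend. They also leave open how much depends on the isothiocyanate itself, a question that an amine at the end of the same chain would address.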